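Compound 3 and the limit of the cytotoxicity assay

The compounds below may be only part of what the source reports. "The series", "measured", "known", "first", "only" and "open" are said of these compounds alone.

compound 1 (`CCOC(=O)c1c(-c2cccc(OC(F)(F)F)c2)[nH]c2cc(OC)ccc2c1=O`) gives > 21500 nM
compound 2 (`CCOC(=O)c1c(-c2cccc(O)c2)[nH]c2cc(OC)ccc2c1=O`) gives > 21500 nM

In an ADME assay on BJ cells (Homo sapiens) for cytotoxicity, read by luminescence, with a stated time of 72 h (a higher number here means that more compound is needed for the effect, a lower number that less compound is needed), compound 1 gives > 21500 nM as a limit and not a number. Compound 2 likewise gives > 21500 nM as a limit. Compound 3 (`CCOC(=O)c1c(-c2cccc(OC(F)(F)F)c2)[nH]c2cc(OC(F)(F)F)ccc2c1=O`) keeps the core of compound 1 and changes one group (trifluoromethyl in place of methyl on an oxygen on an aromatic ring), with trifluoromethyl in place of methyl on an oxygen on an aromatic ring. Among the compounds with values here, the only measured step (a step that the two limits leave unreadable from compound 1 to compound 2) concerns a different group and has no readable size, so it sets no scale for this change. The expectation therefore rests on compound 1 and its limit (> 21500 nM) alone. In this assay no step beyond the scatter is expected (a number no higher from compound 1 to compound 3 (the limit leaves the size open)) and another limit is the likeliest report. Compound 3 is estimated at 21500 nM (range 10000 nM to 45000 nM).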

Compound 3, half-maximal effective concentration: > 21500 nM
Compound 3 ended at the assay's limit (the forecaster's own chance of this, stated with the estimate: 80%); the middle value sits exactly at the limit.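

No step can be read between compound 1, compound 2 and compound 3 in this assay, as each result is a limit and not a number: the limit of > 21500 nM in this assay, at which 3 of the 3 values shown sit.

The compounds shown leave open whether methoxy to trifluoromethoxy changes the half-maximal effective concentration at all, and where that concentration lies for any of them.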